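Two trifluoromethyl-bearing acylureas and an unmeasured partner

The compounds below may be only part of what the source reports. "The series", "measured", "known", "first", "only" and "open" are said of these compounds alone.

Measured compounds in a functional assay on BCG823 cells (Homo sapiens) for inhibition, read by MTT assay, with a stated time of 72 h; a higher number here means a weaker inhibitor, a lower number a stronger inhibitor:
compound 1 `CN(C(=O)NC(=O)c1c(F)cccc1F)c1nc(C(F)(F)F)c(C(=O)N/N=C/c2cccc(C(F)(F)F)c2)s1` gives 25.9 ug/mL
compound 2 `CN(C(=O)NC(=O)c1ccc(C(F)(F)F)cc1)c1nc(C(F)(F)F)c(C(=O)N/N=C/c2ccc(C(F)(F)F)cc2)s1` gives > 100 ug/mL, which is a limit of the assay, not a number
compound 3 `CN(C(=O)NC(=O)c1ccc(C(F)(F)F)cc1)c1nc(C(F)(F)F)c(C(=O)N/N=C/c2cccc(C(F)(F)F)c2)s1` gives 1.84 ug/mL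

Compound 3 and compound 2 share every atom, joined differently: 4-(trifluoromethyl)phenyl in place of 3-(trifluoromethyl)phenyl on a carbon with a double bond to nitrogen. That difference shows an at least 54-fold lower number from compound 2 to compound 3 (1.73 log units; beyond the scatter). Compound 1 differs from compound 3 as 2,6-difluorophenyl in place of 4-(trifluoromethyl)phenyl on a carbonyl carbon, and the step is a 14-fold higher number from compound 3 to compound 1 (1.15 log units; beyond the scatter).

The unmeasured compound 4 `CN(C(=O)NC(=O)c1c(F)cccc1F)c1nc(C(F)(F)F)c(C(=O)N/N=C/c2ccc(C(F)(F)F)cc2)s1` differs from compound 2 as 2,6-difluorophenyl in place of 4-(trifluoromethyl)phenyl on a carbonyl carbon. This is the same change as from compound 3 to compound 1, at the same place. Because compound 2 already sits at the limit of > 100 ug/mL in this assay, at which 1 of the 3 values shown sits, a higher number for compound 4 cannot be resolved by this assay; the step is expected as a step that the limit leaves unreadable from compound 2 to compound 4, resting on the direction seen from compound 3 to compound 1. Compound 4 is therefore expected at 300 ug/mL, most likely again reported only as a limit.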

Compound 4, half-maximal inhibitory concentration: 34.9 ug/mL
The estimate for compound 4 lay 8.6-fold (0.93 log units) above the measured number; the whole stated range lies above it.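

In this assay, putting 2,6-difluorophenyl in place of 4-(trifluoromethyl)phenyl on the carbonyl carbon gives an at least 2.8-fold lower number from compound 2 to compound 4 (0.45 log units; beyond the scatter), so the change did not carry over from one core to the other: the same change on two cores in this assay, a 14-fold higher number (1.15 log units; beyond the scatter) from compound 3 to compound 1 and an at least 2.8-fold lower number (0.45 log units; beyond the scatter) from compound 2 to compound 4, at least 40-fold (1.60 log units) apart, beyond the scatter of two such steps. As far as these compounds go, compound 2 gives > 100 ug/mL, which is a limit of the assay and not a number, so this step is only a bound and its true size remains unknown. Putting 4-(trifluoromethyl)phenyl in place of 3-(trifluoromethyl)phenyl on the carbon with a double bond to nitrogen gives a 1.3-fold higher number from compound 1 to compound 4 (0.13 log units; within the scatter), and this change did not carry over either: the same change on two cores in this assay, an at least 54-fold lower number (1.73 log units; beyond the scatter) from compound 2 to compound 3 and a 1.3-fold lower number (0.13 log units; within the scatter) from compound 4 to compound 1, at least 40-fold (1.60 log units) apart, beyond the scatter of two such steps.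

The compounds shown do not explain why each change depends on the other group. From the compounds shown here alone, whether that dependence extends beyond these groups remains open, for example with a plain phenyl or a methoxyphenyl on the carbonyl carbon.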